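The source may report more compounds than this note shows. Statements on the series, on what has been measured and on what is new or still open speak of the compounds shown alone.

In a functional assay on SGC-7901 cells (Homo sapiens) for cytotoxicity, read by MTT assay, with a stated time of 48 h (on this read-out higher numbers stand for weaker inhibition and lower numbers for stronger inhibition), compound 1 `O=C(CSc1ncccn1)N1N=C(c2cc3ccccc3oc2=O)C[C@@H]1c1ccc(C(F)(F)F)cc1` gives 4390 nM and holds the lower of the two numbers at hand, with compound 2 `CC1=NN(C(=O)CSc2nc3ccccc3s2)[C@@H](c2cc(Br)cc(Br)c2O)C1` at 12300 nM beyond the scatter of it. For the measured compounds named here, compound 3 `CCCCSCC(=O)N1N=C(c2cc3ccccc3oc2=O)C[C@@H]1c1ccc(C(F)(F)F)cc1` keeps the core of compound 1 and carries butyl in place of pyrimidin-2-yl on a sulfur as its one change. Going by the values given here, no measured pair shows this change, so the expectation is a loose one. In this assay no step beyond the scatter is expected, and the estimated 1.5-fold higher number from compound 1 to compound 3 (0.17 log units; within the scatter) leans toward weaker inhibition. For compound 3 the expected value is 6500 nM (estimated range 2500 nM to 17000 nM).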

Compound 3, half-maximal inhibitory concentration: 2910 nM
Compound 3: middle estimate off by 2.2-fold (0.35 log units), on the high side; the measured number falls inside the stated range.
By their numbers in this assay, from the lowest: compounds 3 and 1 (each within the scatter of the next); then compound 2.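

On a sulfur whose other neighbour is a saturated chain carbon, butyl in place of pyrimidin-2-yl gives a 1.5-fold lower number from compound 1 to compound 3 (0.18 log units; within the scatter) in this assay and so does not separate the two compounds. In this pair, the six-membered aromatic ring with its two nitrogens is not needed on this sulfur for a number of this size, and an open chain serves as well. Nothing measured here speaks to the reason.

On these data alone, whether a longer chain such as octyl, a plain phenyl ring, or a chain ending in an amine or a carboxylic acid would hold the same number on this sulfur stays open. So does whether this exchange reads the same on another core.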